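This account rests on a few compounds, and the source may have more. Where it says the series, first, only, none or still open, it means among the compounds named here.

Working notes, series of three measured compounds and one to come.

Values in an assay on membranes from HeLa cells for displacement of a labelled ligand from adenosine receptor A3 (Homo sapiens), read by scintillation counting, with a stated time of 180 min, tested at 1 uM; on this read-out higher numbers stand for more inhibition at the one concentration tested (going by the name of the read-out) and lower numbers for less inhibition:
compound 1 `CCCC(=O)C1=C(C)NC(=O)NC1c1ccoc1` gives 2%
compound 2 `CCCC(=O)C1=C(C)NC(=O)NC1c1ccsc1` gives 1%
compound 3 `CC1=C(C(N)=O)C(c2ccoc2)NC(=O)N1` gives 2%

All three numbers sit close together and none of the gaps among them goes beyond the usual scatter. Going by the values given here, the one change repeated in the set is thiophen-3-yl in place of furan-3-yl on a saturated ring carbon; in this assay it made a number 1 percentage points lower from compound 1 to compound 2 (within the scatter). The cores of compound 1 and compound 3 differ by amino in place of propyl on a carbonyl carbon, with no change at the digits printed from compound 1 to compound 3 (within the scatter).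

Compound 4 `CC1=C(C(N)=O)C(c2ccsc2)NC(=O)N1` is not yet measured. It differs from compound 3 by thiophen-3-yl in place of furan-3-yl on a saturated ring carbon, the same kind of change as made from compound 1 to compound 2, though not the same: in compound 1 the saturated ring carbon is next to the ring atom that bears a propylcarbonyl group, in compound 3 it is next to the ring atom that bears a carbamoyl group.

For compound 4 the expected step is no change at the digits printed from compound 3 to compound 4 (within the scatter), resting on the earlier change having given a number 1 percentage points lower from compound 1 to compound 2 (within the scatter), a step within scatter on the core of compound 1. The estimated value of compound 4 in this assay is 2%, expected to fall between -8% and 12%.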

Compound 4, a percentage reported as inhibition, at one concentration (the size of the read-out at that concentration, not a potency): 1%
Compound 4: the middle estimate sits 1 percentage points above what was measured; the range from low to high includes it.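

In this assay, thiophen-3-yl in place of furan-3-yl on a saturated ring carbon gives a number 1 percentage points lower from compound 3 to compound 4 (within the scatter), and set beside the same change on the core of compound 1, it reads alike: the same change on two cores in this assay, a number 1 percentage points lower (within the scatter) from compound 1 to compound 2 and a number 1 percentage points lower (within the scatter) from compound 3 to compound 4, 0 percentage points apart, within the scatter of two such steps

Amino in place of propyl on a carbonyl carbon gives no change at the digits printed from compound 2 to compound 4 (within the scatter), and this too reads alike on the two cores: the same change on two cores in this assay, no change at the digits printed (within the scatter) from compound 1 to compound 3 and no change at the digits printed (within the scatter) from compound 2 to compound 4, 0 percentage points apart, within the scatter of two such steps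

Going by these compounds alone, this agreement shows only that neither change moved the number beyond the scatter on either core; it does not show that an effect of either change carries from one core to the other, since no step here stands out from the scatter.

The compounds shown leave open whether a phenyl ring on the saturated ring carbon, or a longer chain on the carbonyl carbon, would give a number beyond the scatter of this series. With one concentration in one assay, they also leave open how either change would behave on a core with clear inhibition.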